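A Benzimidazole Sulfonamide Replaces the Isoxazolyl-Thiophene

This account rests on a few compounds, and the source may have more. Where it says the series, first, only, none or still open, it means among the compounds named here.

Measured compounds in an assay on isolated protein for inhibition of coagulation factor X (Oryctolagus cuniculus), tested at 1 uM; on this read-out lower numbers stand for less inhibition and higher numbers for more inhibition at the one concentration tested (going by the name of the read-out):
- Compound 1 `O=C1[C@@H](NS(=O)(=O)c2ccc(-c3ccon3)s2)CCN1Cc1cc2c[nH]ccc-2n1` gave 17%.
- Compound 2 `O=C1[C@@H](NS(=O)(=O)c2ccc(-c3ccon3)s2)CCN1Cc1cc2cc[nH]cc-2n1` gave 49%.
- Compound 3 `O=C1[C@@H](NS(=O)(=O)c2cc3ccnc(Cl)c3s2)CCN1Cc1cc2[nH]cccc-2n1` gave 45%.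

Compound 2 stands highest of the three numbers: compound 3 is within the scatter of it, while compound 1 lies beyond the scatter below it. Among the compounds with values here, the one single-point step in the set, a number 32 percentage points higher from compound 1 to compound 2 (beyond the scatter), concerns the group on the saturated chain carbon bound to the amide-type nitrogen in a ring, not the sulfonyl end.

Compound 4 `O=C1[C@@H](NS(=O)(=O)c2nc3cc(Cl)ccc3[nH]2)CCN1Cc1cc2cc[nH]cc-2n1` differs from compound 2 at the sulfonyl sulfur: 5-chloro-1H-benzimidazol-2-yl in place of 5-(1,2-oxazol-3-yl)thiophen-2-yl on a sulfonyl sulfur. Within the data shown here, no measured step changes a group on the sulfonyl sulfur alone; compound 3 carries a different sulfonyl group but also a different group at the other end, and its value sits within the scatter of compound 2. The expectation for compound 4 therefore rests on little, and a step in either direction in this assay is possible. Compound 4 is estimated at 35%, within 10% to 65%, an expected step of a number 14 percentage points lower from compound 2 to compound 4 (beyond the scatter).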

Compound 4, a percentage reported as inhibition, at one concentration (the size of the read-out at that concentration, not a potency): 21%
Beside the measured number, compound 4's estimate is 14 percentage points above it, within the range that was stated.
By their numbers in this assay, from the lowest: compounds 1 and 4 (each within the scatter of the next); then compounds 3 and 2 (each within the scatter of the next).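

Within the data shown here, this is the first reading of a change on the sulfonyl sulfur alone: in this assay, 5-chloro-1H-benzimidazol-2-yl in place of 5-(1,2-oxazol-3-yl)thiophen-2-yl gives a number 28 percentage points lower from compound 2 to compound 4 (beyond the scatter), with the rest of the molecule unchanged. The sulfonyl end is therefore not indifferent to what it carries, and a change there can move the number beyond the scatter, as the change at the other end did in a number 32 percentage points higher from compound 1 to compound 2 (beyond the scatter). The swap also exchanges hydrogen-bond acceptors for a donor, but nothing at hand accounts for the step or ties it to any one of these differences.

The compounds shown leave open whether the chlorine or the rest of the entering group carries the step. On these data alone, how a benzimidazol-2-yl bearing a methoxy group in place of the chlorine would read, and whether the step holds with a different group on the amide-type nitrogen, also stays open.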